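Replacing a trifluoromethyl benzyl group with an iodo one

The source may report more compounds than this note shows. Statements on the series, on what has been measured and on what is new or still open speak of the compounds shown alone.

In a functional assay on Hs 683 cells (Homo sapiens) for cytotoxicity, read by MTT assay (a lower number here means a stronger inhibitor, a higher number a weaker inhibitor), two compounds with the same core have been measured so far. Compound 1 (`Oc1ccc(CN(Cc2ccccc2C(F)(F)F)Cc2ccc(O)c3ncccc23)c2cccnc12`) gives 64 nM and stands lowest of the two, while compound 2 (`Oc1ccc(CN(Cc2cc(C(F)(F)F)cc(C(F)(F)F)c2)Cc2ccc(O)c3ncccc23)c2cccnc12`) gives 181 nM as the higher number, a gap beyond the usual scatter. Compound 3 (`Oc1ccc(CN(Cc2cccc(I)c2)Cc2ccc(O)c3ncccc23)c2cccnc12`) has not yet been measured. It keeps the core of compound 1 and carries 3-iodophenyl in place of 2-(trifluoromethyl)phenyl on a saturated chain carbon bound to an amine nitrogen. Going by the values given here, no measured pair shows this change on its own, so the two known values are the only guide. With compound 1 at 64 nM as the lower of just two numbers and compound 2 at 181 nM carrying another substituted phenyl group, a small rise rather than a further fall is expected in this assay. That expected move (a 1.7-fold higher number from compound 1 to compound 3 (0.24 log units; within the scatter)) may well stay within the scatter. For compound 3 the estimate is 110 nM spanning 40 nM to 300 nM as its likely range.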

Compound 3, half-maximal inhibitory concentration: 479 nM
Beside the measured number, compound 3's estimate is 4.4-fold (0.64 log units) below it; measured number above the stated range.
By their numbers in this assay, from the lowest: compound 1; then compound 2; then compound 3.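

In this assay, going by these compounds alone, the exchange of 2-(trifluoromethyl)benzyl for 3-iodobenzyl is the first change at this position that can be read on its own, and it weakens the compound: a 7.5-fold higher number from compound 1 to compound 3 (0.87 log units; beyond the scatter), a step well beyond the scatter. The earlier pair of values showed only that two differently substituted phenyl groups give different numbers, whereas this step shows that the aryl group on a saturated chain carbon bound to an amine nitrogen can shift the value substantially while the shared core stays the same. Nothing available explains the size of this step.

The step changes both the substituent, from trifluoromethyl to iodo, and its place on the phenyl ring, so the compounds shown cannot separate these two contributions; a 2-iodobenzyl or a 3-(trifluoromethyl)benzyl group would be needed to tell them apart. Also open, as far as these compounds go, is how this position responds to groups unlike either substituent, such as a methoxy group or a carboxylic acid on the benzyl ring, or to an unsubstituted benzyl group.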